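Trading the hydroxyphenyl end for 3-chlorophenyl

The source may hold more compounds than are shown below. What is called first, only, known or untested is meant among the compounds shown, and "the series" means these compounds.

Compound 1 `Oc1cccc2[nH]c(-c3ccc(-c4ccc(-c5ccc(F)cc5)cc4)cc3)nc12` gives 3010 nM
Compound 2 `Oc1cccc2[nH]c(-c3ccc(-c4ccc(-c5ccc(OC(F)(F)F)cc5)cc4)cc3)nc12` gives 2210 nM
Compound 3 `Oc1ccc(-c2ccc(-c3ccc(-c4nc5c(O)cccc5[nH]4)cc3)cc2)cc1` gives 190 nM

In a functional assay on MCF7 cells (Homo sapiens) for inhibition, read by sulforhodamine B assay (on this read-out higher numbers stand for weaker inhibition of growth and lower numbers for stronger inhibition of growth), compound 3 has the lowest number of the three, and its gaps to both others lie beyond the scatter. Compound 4 `Oc1cccc2[nH]c(-c3ccc(-c4ccc(-c5cccc(Cl)c5)cc4)cc3)nc12` carries 3-chlorophenyl in place of 4-hydroxyphenyl on an aromatic carbon. Two large steps bear on this change: a 16-fold lower number from compound 1 to compound 3 (1.20 log units; beyond the scatter) with hydroxy in place of fluoro, and a 12-fold lower number from compound 2 to compound 3 (1.07 log units; beyond the scatter) with hydrogen in place of trifluoromethyl on the oxygen. By contrast, a 1.4-fold lower number from compound 1 to compound 2 (0.13 log units; within the scatter) with trifluoromethoxy in place of fluoro. Compound 4 has no hydroxy at that end, so it is expected to sit near compound 1 at 3010 nM and compound 2 at 2210 nM rather than near compound 3. Going by the values given here, no measured compound carries a 3-chlorophenyl group, which keeps the range wide. The estimate is a 13-fold higher number from compound 3 to compound 4 (1.12 log units; beyond the scatter) in this assay and so weaker inhibition of growth is expected. For compound 4 the expected value is 2500 nM with a range of 900 nM to 6000 nM.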

Compound 4, concentration for 50% growth inhibition: 3420 nM
Compound 4: the middle estimate sits 1.4-fold (0.14 log units) below what was measured; measured number inside the range.
By their numbers in this assay, from the lowest: compound 3; then compounds 2, 1 and 4 (each within the scatter of the next).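

In this assay, going by these compounds alone, the change gives an 18-fold higher number from compound 3 to compound 4 (1.26 log units; beyond the scatter) while the other two steps, a 1.5-fold higher number from compound 2 to compound 4 (0.19 log units; within the scatter) and a 1.1-fold higher number from compound 1 to compound 4 (0.06 log units; within the scatter) show no separation among the compounds lacking the hydroxy group. At this position, 3-chlorophenyl therefore joins 4-fluorophenyl and 4-(trifluoromethoxy)phenyl, and among the four compounds only compound 3, with its 4-hydroxyphenyl, stands apart. Nothing measured here speaks to what lies behind that gap.

The compounds shown leave open whether the low number belongs to the hydroxy group alone or would also come with an amine or a carboxylic acid at that end. They also leave open whether a methoxy group, or a hydroxy group on 3-hydroxyphenyl, would keep it.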